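Adding a Second Chloro on a Shared Core

This account rests on a few compounds, and the source may have more. Where it says the series, first, only, none or still open, it means among the compounds named here.

Of the compounds shown here, three have so far been measured in a functional assay on NCI-H460 cells (Homo sapiens) for cytotoxicity, read by sulforhodamine B assay, with a stated time of 48 h; a higher number here means a weaker inhibitor of growth, a lower number a stronger inhibitor of growth. Compound 1 `ClCc1ccccc1Cn1cnc2c(Cl)nc(Cl)nc21` gives 8710 nM. Compound 2 `ClCc1ccccc1Cn1cnc2c(Cl)ncnc21` gives 44700 nM. Compound 3 `ClCc1cccc(Cn2cnc3ncnc(Cl)c32)c1` gives 4460 nM, the lowest of the three numbers; compound 1 stands nearest to it, within the scatter, and compound 2 furthest, beyond it.

Compound 2 and compound 1 differ in one place: chloro in place of hydrogen on an aromatic carbon. That change made a 5.1-fold lower number from compound 2 to compound 1 (0.71 log units; beyond the scatter), a modest step.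

Compound 4 `ClCc1cccc(Cn2cnc3nc(Cl)nc(Cl)c32)c1` is not yet measured. It is made from compound 3 by the same change: chloro in place of hydrogen on an aromatic carbon. Compound 3 and compound 2 share the same atoms joined differently, and the difference between their cores is not broken down here.

Within the data shown here, only one earlier example of this change exists, so the expectation rests on a single step. Compound 4 is expected to give about 1000 nM, with a likely range from 350 nM to 3000 nM. This estimate means a step of a 4.5-fold lower number from compound 3 to compound 4 (0.65 log units; beyond the scatter), chosen because the same change from compound 2 to compound 1 made a 5.1-fold lower number from compound 2 to compound 1 (0.71 log units; beyond the scatter).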

Compound 4, concentration for total growth inhibition: 3090 nM
Beside the measured number, compound 4's estimate is 3.1-fold (0.49 log units) below it; the measured number lies above the stated range.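

In this assay, chloro in place of hydrogen on an aromatic carbon gave a 1.4-fold lower number from compound 3 to compound 4 (0.16 log units; within the scatter), so the step seen on the first core was not repeated on the second. The size of this change did not carry over between the two cores in this series: the same change on two cores in this assay, a 5.1-fold lower number (0.71 log units; beyond the scatter) from compound 2 to compound 1 and a 1.4-fold lower number (0.16 log units; within the scatter) from compound 3 to compound 4, 3.6-fold (0.55 log units) apart, beyond the scatter of two such steps. Among these compounds, with only two pairs, this shows that the same change can give steps of different size on these two cores, but it does not show which feature of the cores goes with that difference, as compound 2 and compound 3 share the same atoms joined differently and the difference between their cores is not broken down.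

The compounds shown leave open whether another group on the same aromatic carbon, such as an amine or a methoxy group, would also give different steps on the two cores. They also leave open whether a third core would follow the larger step or the smaller one.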